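Pentyl versus heptyl chains on two amide cores

The compounds below may be only part of what the source reports. "The series", "measured", "known", "first", "only" and "open" are said of these compounds alone.

Compound 2 `CCCCCCCNc1cnc(C(=O)NCc2ccccc2)cn1` and compound 1 `CCCCCNc1cnc(C(=O)NCc2ccccc2)cn1` share one core, while compound 3 `CCCCCCCNc1nccnc1C(=O)NCc1ccccc1` carries the same atoms joined differently; the difference between the two cores is not broken down here. Compound 4 `CCCCCNc1nccnc1C(=O)NCc1ccccc1` stands to compound 3 as compound 1 stands to compound 2. In an ADME assay on MDCK cells (Canis lupus familiaris) for cytotoxicity, read by microscopy, with a stated time of 6 days (on this read-out lower numbers stand for higher toxicity in this test and higher numbers for lower toxicity in this test), compound 2 gives > 100000 nM, which is a limit of the assay rather than a number. In this assay compound 1 likewise gives > 100000 nM, again a limit. Among the compounds with values here, compound 3 is the only member with a number, giving 100000 nM in this assay. The change from compound 2 to compound 1 is hydrogen in place of ethyl on a saturated chain carbon, five bonds along the chain from a nitrogen on an aromatic ring, and its step that the two limits leave unreadable from compound 2 to compound 1 stays unreadable because the limit of > 100000 nM in this assay, at which 2 of the 3 values shown sit, holds both of its ends. The change from compound 3 to compound 4 is hydrogen in place of ethyl on a saturated chain carbon, five bonds along the chain from a nitrogen on an aromatic ring, the same change placed on the other core. For compound 4 the expected step of a 1.2-fold higher number from compound 3 to compound 4 (0.08 log units; within the scatter) is small. That expectation rests on compound 3 at 100000 nM and on the unreadable step from compound 2 to compound 1, which gives no sign of a large shift. Compound 4 is therefore estimated at 120000 nM, expected between 50000 nM and 300000 nM.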

Compound 4, minimum cytotoxic concentration: >= 20000 nM
Compound 4 ended at the assay's limit; the forecaster's own chance of this, stated with the estimate: 50%; the middle value lies beyond the limit too.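

In this assay compound 4 gives >= 20000 nM, a limit of the assay and not a number. No new step can be read, as the one from compound 3 to compound 4 ends at a limit: the limit of >= 20000 nM in this assay, at which 1 of the 4 values shown sits.

On these data alone, whether going from heptyl to pentyl shifts cytotoxicity on either core stays open.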